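A few compounds are considered here, and "the series" means these few. Any claim that something is new, unique, unknown or untested is made for them only; others in the source may bear on it.

Measured so far:
In a functional assay (aorta) for antagonist activity, with Oryctolagus cuniculus as the target (on this read-out higher numbers stand for weaker inhibition and lower numbers for stronger inhibition), compound 1 `CCCCc1ccc(CNS(=O)(=O)c2ccc(C)cc2)c(=O)n1Cc1ccc(-c2ccccc2-c2nn[nH]n2)cc1` gives 9 nM.
In this assay compound 2 `CCCCc1ccc(CN(C)S(=O)(=O)c2ccccc2)c(=O)n1Cc1ccc(-c2ccccc2-c2nn[nH]n2)cc1` gives 2 nM.

For the measured compounds named here, compound 2 stands at the lowest of the two numbers; the single step, a 4.5-fold lower number from compound 1 to compound 2 (0.65 log units; beyond the scatter), separates it from compound 1. Compound 3 `CCCCc1ccc(CN(Cc2ccccc2)S(C)(=O)=O)c(=O)n1Cc1ccc(-c2ccccc2-c2nn[nH]n2)cc1` differs from compound 2 by benzyl(methylsulfonyl)amino in place of methyl(phenylsulfonyl)amino on a saturated chain carbon bound to an aromatic carbon. Going by the values given here, no measured step makes a change of this kind, so that one step, which concerned a different change, is the only guide and does not bear directly on it. Compound 3 is therefore expected to stay near compound 2, with an expected step of a 2.5-fold higher number from compound 2 to compound 3 (0.40 log units; beyond the scatter) and an estimated value of 5 nM, in the range 1.5 nM to 20 nM.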

Compound 3, half-maximal inhibitory concentration: 2 nM
Compound 3: middle estimate off by 2.5-fold (0.40 log units), on the high side, within the range that was stated.
By their numbers in this assay, from the lowest: compounds 2 and 3 (each within the scatter of the next); then compound 1.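

In this assay, the group on the saturated chain carbon bound to an aromatic carbon can be exchanged for one with its aromatic ring carried on the nitrogen as benzyl, and the sulfonyl bearing only methyl, with no change at the digits printed from compound 2 to compound 3 (within the scatter). For the compounds shown here, the step of a 4.5-fold lower number from compound 1 to compound 3 (0.65 log units; beyond the scatter) matches the one to compound 2, so both groups without the sulfonamide hydrogen lie below compound 1, though each step also changes other parts of the group. Nothing available explains this. On these data alone, whether the sulfonyl itself is needed remains open. So does whether a carboxylic acid or a simple amine at this place would fare the same.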